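The source may report more compounds than this note shows. Statements on the series, on what has been measured and on what is new or still open speak of the compounds shown alone.

The compounds measured so far, each with its value in a functional assay for inhibition, with Homo sapiens as the target; a lower number here means a stronger inhibitor, a higher number a weaker inhibitor:

Compound 1, `Cc1ncc2cnnc(O)n12`, gives > 48000 nM, which is a limit of the assay and not a number.
Compound 2, `CCc1nc(C)c2cnnc(O)n12`, gives > 48000 nM, likewise a limit of the assay.
Compound 3, `Cc1ncc2cnnc(S)n12`, gives > 48000 nM, again a limit of the assay.

In this assay none of the three compounds reached a measurable number. Compound 3 differs from compound 1 by one change, (sulfanyl in place of hydroxy on an aromatic carbon), and the step this made, a step that the two limits leave unreadable from compound 1 to compound 3, cannot be read in size, since both values sit at the same limit; what is shown is only (the limit of > 48000 nM in this assay, at which 3 of the 3 values shown sit). Compound 2 and compound 1 carry different cores, and the difference between the two cores is not broken down here. For compound 2 only a limit stands in this assay.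

Compound 4, `CCc1nc(C)c2cnnc(S)n12`, has not yet been measured in this assay. It differs from compound 2 by sulfanyl in place of hydroxy on an aromatic carbon, the same change as that from compound 1 to compound 3, since both place descriptions agree word for word. Because compound 1 and compound 3 both sit at the limit in the limit of > 48000 nM in this assay, at which 3 of the 3 values shown sit, and compound 2 sits there too, the step from compound 2 to compound 4 is expected to be about a step that the limit leaves unreadable from compound 2 to compound 4, that is, no readable change. Compound 4 is therefore expected to give around 100000 nM, most likely again reported only as a limit, with a range estimated from 30000 nM to 500000 nM.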

Compound 4, half-maximal inhibitory concentration: > 48000 nM
Compound 4: no number, only a limit; the forecaster's own chance of this, stated with the estimate: 85%; the middle value is on the limit's open side.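

In this assay compound 4 gives > 48000 nM as a limit of the assay and not a number. Compound 2 stands at the same limit, so no step from compound 2 to compound 4 can be read: the limit of > 48000 nM in this assay, at which 4 of the 4 values shown sit.

The compounds shown leave open whether sulfanyl in place of hydroxy changes inhibition at all, and what number any of the four compounds would give.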